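The compounds below may be only part of what the source reports. "The series", "measured", "known", "first", "only" and "open" are said of these compounds alone.

Of the compounds shown here, two sharing one core have been measured so far in a physicochemical assay for solubility, at pH 6.6; a lower number here means a less soluble compound, a higher number a more soluble compound. Compound 1 `CC(c1ccccc1)c1nc2c(C(F)(F)F)cccc2c(C(=O)O)c1O` gives 1550 ug/mL, and compound 2 `CC(C)(c1ccccc1)c1nc2c(C(F)(F)F)cccc2c(C(=O)O)c1O` gives 2810 ug/mL. With only these two numbers available, compound 2 stands level with compound 1, since the gap between them lies within the scatter of repeat measurements.

Compound 3 `CCC(c1ccccc1)c1nc2c(C(F)(F)F)cccc2c(C(=O)O)c1O` has the same atoms as compound 2, joined differently: 1-phenylpropyl in place of 1-methyl-1-phenylethyl on an aromatic carbon. The group involved is 1-phenylpropyl in place of 1-methyl-1-phenylethyl on an aromatic carbon, and the rest of the molecule stays the same.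

For the measured compounds named here, only one measured step bears on this change. It is a 1.8-fold higher number from compound 1 to compound 2 (0.26 log units; within the scatter), produced by methyl in place of hydrogen in this same side group. That single step gives thin evidence, but it offers no reason to predict a large shift, so no step beyond the scatter is expected in this assay. The expected step is a 1.4-fold lower number from compound 2 to compound 3 (0.15 log units; within the scatter). For compound 3 the estimated value is 2000 ug/mL, with an expected range from 1000 ug/mL to 4000 ug/mL.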

Compound 3, solubility: 600 ug/mL
Compound 3: middle estimate off by 3.3-fold (0.52 log units), on the high side; measured number below the stated range.
By their numbers in this assay, from the lowest: compound 3; then compounds 1 and 2 (each within the scatter of the next).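

Moving a carbon within this side group matters at this position, next to the ring nitrogen. 1-Phenylpropyl and 1-methyl-1-phenylethyl have the same heavy atoms, yet replacing the second with the first gives a 4.7-fold lower number from compound 2 to compound 3 (0.67 log units; beyond the scatter) in this assay, so the atom count of the group does not settle the outcome here. The place of an added methyl also counts: on the chain carbon bound to the two aromatic carbons it gives a 1.8-fold higher number from compound 1 to compound 2 (0.26 log units; within the scatter), whereas on the chain carbon two bonds along from them it gives a 2.6-fold lower number from compound 1 to compound 3 (0.41 log units; beyond the scatter), and no measurement at hand explains why these two placements differ.

On these data alone, with only these three side groups, it stays open whether the lower number follows from the chain reaching further from the carbon bound to the ring or from something particular to 1-phenylpropyl. A longer chain such as 1-phenylbutyl, or an amine or a hydroxy group placed on that same chain, would show whether the trend continues or whether a different kind of atom at that spot changes the picture.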